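The source may hold more compounds than are shown below. What is called first, only, known or untested is meant among the compounds shown, and "the series" means these compounds.

The three measured compounds share one core and differ only in the group on the oxygen on a saturated carbon. Compound 1 `Cc1ccc(-c2csc(NC(=O)COc3ccccc3)n2)cc1` carries a plain phenyl there, and in a functional assay on MDA-MB-468 cells (Homo sapiens) for cytotoxicity, read by trypan blue exclusion, with a stated time of 48 h (a higher number here means a weaker inhibitor, a lower number a stronger inhibitor), compound 1 gives 54500 nM. Compound 2 `Cc1ccc(-c2csc(NC(=O)COc3ccc(Cl)c(C)c3)n2)cc1` carries 4-chloro-3-methylphenyl, and in this assay compound 2 gives 54700 nM; the step is a 1.0-fold higher number from compound 1 to compound 2 (0.00 log units; within the scatter). Compound 3 `Cc1ccc(-c2csc(NC(=O)COc3ccc(F)cc3F)n2)cc1` carries 2,4-difluorophenyl, and in this assay compound 3 gives 10200 nM, the lowest of the three numbers, reached by a 5.3-fold lower number from compound 1 to compound 3 (0.73 log units; beyond the scatter) and by a 5.4-fold lower number from compound 2 to compound 3 (0.73 log units; beyond the scatter).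

Compound 4 `O=C(COc1ccc(F)cc1F)Nc1nc(-c2ccc(Cl)cc2)cs1` keeps the 2,4-difluorophenyl of compound 3 and alters the other end of the molecule instead: chloro in place of methyl on an aromatic carbon. Within the data shown here, none of the three measured steps touches that position; each of them exchanges the group on the oxygen on a saturated carbon, so no measured step bears directly on the change from compound 3 to compound 4. Among the measured compounds shown here, compound 3 is the only anchor, and with no comparable precedent the change is treated as neutral. For compound 4 the estimated step is a 1.0-fold lower number from compound 3 to compound 4 (0.01 log units; within the scatter), within the scatter, in no particular direction, with a wide range to reflect the missing precedent. Compound 4 is therefore expected to give about 10000 nM in this assay, with a range from 3000 nM to 35000 nM.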

Compound 4, half-maximal inhibitory concentration: 32300 nM
Beside the measured number, compound 4's estimate is 3.2-fold (0.51 log units) below it; the range from low to high includes it.
By their numbers in this assay, from the lowest: compound 3; then compounds 4, 1 and 2 (each within the scatter of the next).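

The change from 4-methylphenyl to 4-chlorophenyl is the first shown at this end of the molecule, and in this assay it gives a 3.2-fold higher number from compound 3 to compound 4 (0.50 log units; beyond the scatter). Among these compounds, this position, on the six-membered aromatic ring of carbon only and para to a large group, therefore responds to the exchange of a single heavy atom, with methyl giving the stronger inhibitor of this pair; the earlier steps, all confined to the group on the oxygen, could not show this. Nothing available explains why chloro gives the weaker result here, and the numbers record only the size and direction of the step.

Going by these compounds, this pair shows the exchange only with 2,4-difluorophenyl on the oxygen, so it remains open whether the same step would appear with the plain phenyl of compound 1 or the 4-chloro-3-methylphenyl of compound 2. On these data alone, it is also open how this position would respond to other groups in the same place, such as fluoro, methoxy or an amine, and whether methyl and chloro mark the ends of a wider range or lie close together within it.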